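This account rests on a few compounds, and the source may have more. Where it says the series, first, only, none or still open, it means among the compounds named here.

Working notes on the series. In a functional assay on MOLT-4 cells (Homo sapiens) for cytotoxicity, read by sulforhodamine B assay, with a stated time of 24 h (a lower number here means a stronger inhibitor of growth, a higher number a weaker inhibitor of growth), the two measured compounds share one core and differ only at the oxygen on the pendant ring. Compound 1 `COc1ccc(C(=O)/C=C/c2cc3ccccc3[nH]c2=O)cc1` carries a methoxy group, compound 2 `O=C(/C=C/c1cc2ccccc2[nH]c1=O)c1ccc(O)cc1` a hydroxy group. For compound 1 the result is a limit of the assay, > 100000 nM, as recorded under (the limit of > 100000 nM in this assay, at which 1 of the 2 values shown sits). Within the data shown here, compound 2 gives 9910 nM, the only actual number in the set. Among the measured compounds shown here, the single measured step is an at least 10-fold lower number from compound 1 to compound 2 (1.00 log units; beyond the scatter). Compound 3 `O=C(/C=C/c1cc2ccccc2[nH]c1=O)c1ccc(Cl)cc1` is not yet measured; its change from compound 2 reads (chloro in place of hydroxy on an aromatic carbon). For the measured compounds named here, no measured step is of the same kind, but because an at least 10-fold lower number from compound 1 to compound 2 (1.00 log units; beyond the scatter) favours the hydroxy over the methoxy, and compound 3 carries no hydroxy either, a higher number is expected, with a fair chance of a limit. The expected step is a 3.5-fold higher number from compound 2 to compound 3 (0.55 log units; beyond the scatter). The estimate for compound 3 is 35000 nM, expected between 8000 nM and 150000 nM.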

Compound 3, concentration for total growth inhibition: > 100000 nM
Compound 3 gave a limit, no number (the forecaster's own chance of this, stated with the estimate: 35%); at least 2.8-fold (0.45 log units) between middle value and limit.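

In this assay, the change from 4-hydroxyphenyl to 4-chlorophenyl gives an at least 10-fold higher number from compound 2 to compound 3 (1.00 log units; beyond the scatter), so a second replacement of the hydroxy, this time by chloro, also leaves no actual number. Among the three compounds, only the hydroxy on this aromatic carbon, para to a large group, yields a number, and no compound shown goes against this. The step between the methoxy and chloro compounds cannot be read, so those two groups cannot be put in order, and both results are limits, not numbers: the limit of > 100000 nM in this assay, at which 2 of the 3 values shown sit.

On these data alone, whether an amine or a carboxylic acid at this place would also yield a number remains open. Also open, as far as these compounds go, is how a hydroxy would behave elsewhere on the six-membered aromatic ring.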